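Cytotoxicity notes on a bromoquinoline triazole series

This account rests on a few compounds, and the source may have more. Where it says the series, first, only, none or still open, it means among the compounds named here.

Measured compounds:
- compound 1 `COc1nc2ccc(Br)cc2cc1C(c1ccccc1)n1cc(-c2cccc(F)c2)nn1`: 6.84%
- compound 2 `CCCCCCCCc1cn(C(c2ccccc2)c2cc3cc(Br)ccc3nc2OC)nn1`: 14.6%
- compound 3 `COc1nc2ccc(Br)cc2cc1C(c1ccccc1)n1cc(-c2ccc(F)cc2)nn1`: 4.04%

In an ADME assay on HEK293 cells (Homo sapiens) for cytotoxicity, read by sulforhodamine B assay, with a stated time of 48 h, tested at 10 uM (a lower number here means less inhibition, a higher number more inhibition at the concentration tested (going by the name of the read-out)), compound 3 gives the lowest of the three numbers. Among the measured compounds shown here, its nearest neighbour is compound 1, with a step of a number 2.8 percentage points lower from compound 1 to compound 3 (within the scatter); the furthest is compound 2, with a step of a number 10.6 percentage points lower from compound 2 to compound 3 (beyond the scatter), the only step in this small set that lies beyond the scatter. The third measured step is a number 7.8 percentage points higher from compound 1 to compound 2 (within the scatter).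

Compound 4 `COc1nc2ccc(Br)cc2cc1C(c1ccccc1)n1cc(CCO)nn1` is not yet measured. Its change against compound 3 is 2-hydroxyethyl in place of 4-fluorophenyl on an aromatic carbon. For the measured compounds named here, no measured step swaps an aromatic ring for a short hydroxyl-bearing chain at this position; the closest comparison is the exchange of an aromatic ring for octyl, which gave a modest step only in one direction. With nothing closer to lean on, no step beyond the scatter is expected in this assay for compound 4.

The estimate for compound 4 in this assay is 5%, with a range from -5% to 15%. The step this estimate means, a number 1 percentage points higher from compound 3 to compound 4 (within the scatter), is expected to stay within the scatter.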

Compound 4, a percentage reported as inhibition, at one concentration (the size of the read-out at that concentration, not a potency): 4.54%
Compound 4: the middle estimate sits 0.5 percentage points above what was measured; the range from low to high includes it.
By their numbers in this assay, from the lowest: compounds 3, 4, 1 and 2 (each within the scatter of the next, the first and the last beyond it).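

In this assay, a 2-hydroxyethyl chain on this aromatic carbon reads the same as a fluorophenyl ring, whichever ring it replaces: a number 0.5 percentage points higher from compound 3 to compound 4 (within the scatter), and a number 2.3 percentage points lower from compound 1 to compound 4 (within the scatter). So a group with no ring, fewer heavy atoms and a hydrogen-bond donor leaves the number where the two aryl compounds put it, while the octyl chain is the only group that gives a step beyond the scatter, now seen a second time in a number 10.1 percentage points lower from compound 2 to compound 4 (beyond the scatter). Nothing at hand accounts for these readings.

On these data alone, whether an amine or a carboxylic acid on the same carbon would also stay in this range remains open. So does the point along the chain, between 2-hydroxyethyl and octyl, at which the number starts to separate, and whether a longer chain ending in hydroxy behaves like compound 4 or like compound 2.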